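A few compounds are considered here, and "the series" means these few. Any claim that something is new, unique, unknown or untested is made for them only; others in the source may bear on it.

Compound 1 `O=C(Nc1cccc(-n2cc(-c3ccncc3)c(-c3cc(O)cc(Cl)c3)n2)c1)Nc1ccc(Cl)c(C(F)(F)F)c1` has been measured in a functional assay on MDA-MB-468 cells (Homo sapiens) for inhibition, read by sulforhodamine B assay, with a stated time of 48 h, tested at 100 uM (on this read-out higher numbers stand for a weaker effect at the one concentration tested and lower numbers for a stronger effect), where compound 1 gives -29%. Going by the values given here, this is the lowest of the two numbers known. Its nearest neighbour is compound 2 `O=C(Nc1cccc(-n2cc(-c3ccncc3)c(-c3cc(O)cc(Cl)c3)n2)c1)Nc1ccc(Cl)c(Cl)c1`, which in this assay gives -17%. Among the compounds with values here, the only measured step, a number 12 percentage points higher from compound 1 to compound 2 (beyond the scatter), exchanges a chloro for a trifluoromethyl on an aromatic carbon and leaves the rest of the molecule untouched. Compound 3 `COc1cc(Cl)cc(-c2nn(-c3cccc(NC(=O)Nc4ccc(Cl)c(C(F)(F)F)c4)c3)cc2-c2ccncc2)c1` has not yet been measured. It differs from compound 1 by methyl in place of hydrogen on an oxygen on an aromatic ring. Within the data shown here, the one known step changes a different part of the molecule and does not bear on this hydroxy-to-methoxy change. Nothing in the data points to a move beyond the scatter in this assay in either direction. The step is expected to be small, a number 7 percentage points higher from compound 1 to compound 3 (within the scatter). The estimate for compound 3 is -22%, within a range from -55% to 10%.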

Compound 3, a percentage reported as activity, at one concentration (the size of the read-out at that concentration, not a potency): -27%
For compound 3 the middle estimate is 5 percentage points above the measured one, and the stated range covers the measured number.
By their numbers in this assay, from the lowest: compounds 1, 3 and 2 (each within the scatter of the next, the first and the last beyond it).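

Replacing the hydrogen of the hydroxy group with methyl, which turns 3-chloro-5-hydroxyphenyl into 3-chloro-5-methoxyphenyl, is the first change shown at this position, and in this assay it gives a number 2 percentage points higher from compound 1 to compound 3 (within the scatter) with no measurable effect on the read-out. The free hydroxy hydrogen is therefore not required for the effect seen at the single concentration tested, at least with the rest of compound 1 unchanged. Nothing available explains why this change makes so little difference.

Still open, going by these compounds, is whether a group that differs more from hydroxy, such as an amine, a carboxylic acid or a longer chain like ethoxy, would stay as close to compound 1. Also open, on these data alone, is whether hydroxy to methoxy would behave the same way with the dichlorophenyl urea of compound 2.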